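The compounds below may be only part of what the source reports. "The series", "measured", "known", "first", "only" and "open" are said of these compounds alone.

Measured compounds:
compound 1, `COc1ccc(N2CCN(CC(=O)N3CCN(c4nnc(-c5ccccc5)c(-c5ccccc5)n4)CC3)CC2)cc1`: > 910000 nM
compound 2, `O=C(CN1CCN(c2ccc(Cl)cc2)CC1)N1CCN(c2nnc(-c3ccccc3)c(-c3ccccc3)n2)CC1`: 56300 nM
compound 3, `COc1cccc(N2CCN(CC(=O)N3CCN(c4nnc(-c5ccc(C)cc5)c(-c5ccc(C)cc5)n4)CC3)CC2)c1`: 867000 nM

Of the compounds shown here, three have been tested in a functional assay on MCF7 cells (Homo sapiens) for cytotoxicity, read by MTT assay, with a stated time of 24 h; a lower number here means a stronger inhibitor, a higher number a weaker inhibitor. Compound 1 gives > 910000 nM, which is a limit of the assay and not a number (the limit of > 910000 nM in this assay, at which 1 of the 3 values shown sits). Compound 2 gives 56300 nM. The step of an at least 16-fold lower number from compound 1 to compound 2 (1.20 log units; beyond the scatter) rests on a single change, (chloro in place of methoxy on an aromatic carbon). Compound 3 gives 867000 nM, the higher of the two numbers reported, its nearest neighbour in value being compound 2. The difference between the core of compound 1 and the core of compound 3 is not broken down here.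

Compound 4, `Cc1ccc(-c2nnc(N3CCN(C(=O)CN4CCN(c5cccc(Cl)c5)CC4)CC3)nc2-c2ccc(C)cc2)cc1`, has not yet been measured in this assay. It differs from compound 3 by chloro in place of methoxy on an aromatic carbon. Among the measured compounds shown here, this is the same kind of change as the one between compound 1 and compound 2, not the same: there the group sits "para to a large group", here "meta to a large group", and the two cores differ. For compound 4 the expected step is an 11-fold lower number from compound 3 to compound 4 (1.03 log units; beyond the scatter), a clear lowering of the number. This expectation rests on the measured step of an at least 16-fold lower number from compound 1 to compound 2 (1.20 log units; beyond the scatter), which ran in the same direction on the other core. Compound 4 is accordingly estimated at 80000 nM, with a range from 20000 nM to 400000 nM.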

Compound 4, half-maximal inhibitory concentration: 797000 nM
The estimate for compound 4 lay 10-fold (1.00 log units) below the measured number; measured number above the stated range.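

In this assay, chloro in place of methoxy on an aromatic carbon gives a 1.1-fold lower number from compound 3 to compound 4 (0.04 log units; within the scatter), and the larger lowering seen on the other core does not carry over: the same change on two cores in this assay, an at least 16-fold lower number (1.20 log units; beyond the scatter) from compound 1 to compound 2 and a 1.1-fold lower number (0.04 log units; within the scatter) from compound 3 to compound 4, at least 14-fold (1.17 log units) apart, beyond the scatter of two such steps The change is therefore not transferable as a fixed step between these two cores, but the two pairs differ both in the core and in where the group sits on the ring, and each is a single pair, so these data do not show which of the two differences decides the outcome. The value of compound 1, > 910000 nM, is a limit of the assay and not a number: the limit of > 910000 nM in this assay, at which 1 of the 4 values shown sits.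

Still open, from the compounds shown here alone, is whether the same swap, made at the same place on the ring on both cores, gives matching steps, which would separate the effect of the core from that of the place. Also open, going by these compounds, is how other groups on this ring, such as fluoro, a nitrile, an amine or a carboxylic acid, would read on either core in this assay.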